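The source may hold more compounds than are shown below. What is called first, only, known or untested is meant among the compounds shown, and "the series" means these compounds.

Measured compounds:
compound 1, `COc1ccccc1-c1cn(C[C@H](O)[C@H]2OC(=O)C(OCc3ccccc3)=C2OCc2ccccc2)nn1`, in a functional assay on HeLa cells (Homo sapiens) for antiproliferative activity, read by MTT assay, with a stated time of 72 h (on this read-out lower numbers stand for stronger inhibition and higher numbers for weaker inhibition), gives > 100000 nM;
compound 2, `O=C1O/C(=C\Cn2cc(-c3cc(C(F)(F)F)cc(C(F)(F)F)c3)nn2)C(OCc2ccccc2)=C1OCc1ccccc1`, in this assay gives > 100000 nM.

Both numbers for compound 1 and compound 2 are limits of this assay, not measured values. For the measured compounds named here, compound 1 therefore stands at the edge of what this assay can report, and the same holds for the only other compound measured here; no step between two measured compounds is available, because the limit of > 100000 nM in this assay, at which 2 of the 2 values shown sit, describes where every value so far sits.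

Compound 3, `COc1ccc(-c2cn(C[C@H](O)[C@H]3OC(=O)C(OCc4ccccc4)=C3OCc3ccccc3)nn2)cc1`, is yet to be measured. It is built from the same atoms as compound 1, joined differently: 4-methoxyphenyl in place of 2-methoxyphenyl on an aromatic carbon. The shared core of compound 1, with its benzyloxy-bearing lactone, the secondary alcohol and the five-membered ring with three nitrogens, is kept unchanged.

Going by the values given here, with no measured step to lean on, the account expects no change beyond the scatter in this assay, and the step from compound 1 to compound 3 is estimated at a step that the limit leaves unreadable from compound 1 to compound 3. Compound 3 is accordingly estimated at 150000 nM, within a range from 40000 nM to 500000 nM, most probably reported again as a limit rather than a number.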

Compound 3, half-maximal inhibitory concentration: 16400 nM
The estimate for compound 3 lay 9.1-fold (0.96 log units) above the measured number; the whole stated range lies above it.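

In this assay, for the compounds shown here, 4-methoxyphenyl in place of 2-methoxyphenyl, on an aromatic carbon of the five-membered aromatic ring with 3 nitrogen, gives an at least 6.0-fold lower number from compound 1 to compound 3 (0.78 log units; beyond the scatter), and compound 3 is the first compound here to return a number rather than a limit. This position therefore responds in this assay: the two groups carry the same atoms and the same counts of donors and acceptors, so the atoms alone do not fix the read-out, and how they are joined is enough to move the value within this shared core. The size of the step is only a lower bound, because compound 1 sits at a limit: the limit of > 100000 nM in this assay, at which 2 of the 3 values shown sit.

On these data alone, it remains open whether the methoxy group itself matters at this place, or whether a plain phenyl, a 4-hydroxyphenyl or a 4-aminophenyl on the same carbon would read the same as 4-methoxyphenyl. Also open, as far as these compounds go, is how 3-methoxyphenyl would fall relative to compound 1 and compound 3, and whether the same exchange would have any effect on the core of compound 2.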